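Difluoromethoxy for trifluoromethyl: expected cytotoxicity of compound 3

The source may report more compounds than this note shows. Statements on the series, on what has been measured and on what is new or still open speak of the compounds shown alone.

Compound 1 `O=[N+]([O-])c1cn2c(n1)OC[C@@H](OCc1cccc(-c3ccc(OC(F)(F)F)cc3)c1)C2` and compound 2 `O=[N+]([O-])c1cn2c(n1)OC[C@@H](OCc1ccc(-c3ccc(C(F)(F)F)cc3)s1)C2` were both tested in an ADME assay on Vero cells (Chlorocebus sabaeus) for cytotoxicity, with a stated time of 72 h; a lower number here means a stronger inhibitor, a higher number a weaker inhibitor. In this assay compound 1 reaches only the limit of the assay, > 128000 nM, not a measured number. Compound 2 likewise reaches only the limit, > 128000 nM, in this assay. Both thus sit at the same boundary, (the limit of > 128000 nM in this assay, at which 2 of the 2 values shown sit). Compound 3 `O=[N+]([O-])c1cn2c(n1)OC[C@@H](OCc1ccc(-c3ccc(OC(F)F)cc3)s1)C2` differs from compound 2 by difluoromethoxy in place of trifluoromethyl on an aromatic carbon. The expected step that the limit leaves unreadable from compound 2 to compound 3 is essentially none beyond the scatter. Compound 3 is therefore estimated at 150000 nM, within 64000 nM to 400000 nM, most likely again reported only as a limit.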

Compound 3, half-maximal inhibitory concentration: > 128000 nM
Compound 3 ended at the assay's limit; the forecaster's own chance of this, stated with the estimate: 85%; the middle value does not contradict the limit.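

Among the compounds shown here, compound 2 and compound 3 both sit at the limit of this assay rather than at a measured number, so no step between them can be read. From the compounds shown here alone, how far either compound lies beyond that limit remains open.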